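Urea to Benzamide on a Pyrazole Scaffold

The source may report more compounds than this note shows. Statements on the series, on what has been measured and on what is new or still open speak of the compounds shown alone.

Compound 1 `COc1cc(-c2nn(-c3cccc(NC(=O)Nc4cccc(C(F)(F)F)c4)c3)cc2-c2ccncc2)ccc1Cl`: 936 nM
Compound 2 `COc1cc(-c2nn(-c3cccc(NC(=O)Nc4ccc(Cl)c(C(F)(F)F)c4)c3)cc2-c2ccncc2)ccc1Cl`: 1020 nM

In a functional assay on MOLT-4 cells (Homo sapiens) for inhibition, read by sulforhodamine B assay, with a stated time of 48 h (a higher number here means a weaker inhibitor of growth, a lower number a stronger inhibitor of growth), compound 2 gives 1020 nM, which is the higher of the two numbers; compound 1 is nearest, and the change from compound 1 to compound 2 was a 1.1-fold higher number from compound 1 to compound 2 (0.04 log units; within the scatter). Compound 3 `COc1cc(-c2nn(-c3cccc(NC(=O)c4ccccc4)c3)cc2-c2ccncc2)ccc1Cl` differs from compound 2 by phenyl in place of (4-chloro-3-(trifluoromethyl)phenyl)amino on a carbonyl carbon. Among the compounds with values here, the only measured step changes a different part of the molecule, so it does not speak directly to this replacement. Within the data shown here, with no step to guide the direction, a weakening is expected, and compound 3 is estimated at 3500 nM (range 1000 nM to 12000 nM), an expected step of a 3.4-fold higher number from compound 2 to compound 3 (0.54 log units; beyond the scatter).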

Compound 3, concentration for 50% growth inhibition: 701 nM
Estimate against measurement, compound 3: 5.0-fold (0.70 log units) above; the measured number lies below the stated range.
By their numbers in this assay, from the lowest: compounds 3, 1 and 2 (each within the scatter of the next).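

In this assay the carbonyl carbon tolerates phenyl in place of either arylamino group, with both steps within the scatter: replacing (4-chloro-3-(trifluoromethyl)phenyl)amino gives one step (a 1.5-fold lower number from compound 2 to compound 3 (0.16 log units; within the scatter)) and replacing (3-(trifluoromethyl)phenyl)amino gives the other (a 1.3-fold lower number from compound 1 to compound 3 (0.13 log units; within the scatter)). The entering phenyl has 6 heavy atoms and 0 hydrogen-bond donors, where (4-chloro-3-(trifluoromethyl)phenyl)amino has 12 heavy atoms and 1 hydrogen-bond donor, yet the number stays within the scatter. No available evidence accounts for this result.

On these data alone, it remains open whether an amine or a carboxylic acid on the phenyl, or a longer chain at this carbonyl carbon, would move the number beyond the scatter.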